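Isobutyl for 4-fluorophenyl at the chain carbon

A few compounds are considered here, and "the series" means these few. Any claim that something is new, unique, unknown or untested is made for them only; others in the source may bear on it.

Compound 3 `CC1(C)CC(NC(=O)C(/C=C/[C@H](NC(=O)OC(C)(C)C)c2ccc(F)cc2)(Cc2ccc(F)cc2)Cc2ccc(F)cc2)CC(C)(C)N1` gives 7.9 in a physicochemical assay for lipophilicity; on this read-out lower numbers stand for lower lipophilicity and higher numbers for higher lipophilicity. It stands level with compound 2 `CC1(C)CC(NC(=O)C(/C=C/[C@@H](NC(=O)OC(C)(C)C)c2ccc(F)cc2)(Cc2ccc(F)cc2)Cc2ccc(F)cc2)CC(C)(C)N1`, which gives 7.9; the two are together the highest of the three numbers. Compound 1 `CC(C)C[C@@H](/C=C/C1(C(=O)NC2CC(C)(C)NC(C)(C)C2)CCCC1)NC(=O)OC(C)(C)C` is furthest away and gives 4.4, a gap beyond the scatter, but it differs from compound 3 in more than one place, so the two values are noted only side by side.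

For the measured compounds named here, the step from compound 2 to compound 3 is the one measured single change: no change at the digits printed from compound 2 to compound 3 (within the scatter). It rests on the fact that compounds 2 and 3 differ only in the configuration as drawn and touches no group, so it says nothing about an exchange of substituents.

Compound 4 `CC(C)C[C@H](/C=C/C(Cc1ccc(F)cc1)(Cc1ccc(F)cc1)C(=O)NC1CC(C)(C)NC(C)(C)C1)NC(=O)OC(C)(C)C` differs from compound 3 by isobutyl in place of 4-fluorophenyl on a saturated chain carbon bound to an amide-type nitrogen and a double-bonded chain carbon. Going by the values given here, no measured pair covers this exchange at that position; the only step is one of configuration and leaves the read-out unchanged. The step in this assay for compound 4 is therefore taken as small, pointing downward if anywhere, and is expected to be about a number 0.30 log units lower from compound 3 to compound 4 (within the scatter). Compound 4 is estimated at 7.6, with a range from 6.9 to 8.3.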

Compound 4, partition coefficient: 7.6
For compound 4 middle estimate and measured number coincide at the digits printed, within the range that was stated.
By their numbers in this assay, from the lowest: compound 1; then compounds 4, 2 and 3 (each within the scatter of the next).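

In this assay, for the compounds shown here, isobutyl in place of 4-fluorophenyl on a saturated chain carbon bound to an amide-type nitrogen and a double-bonded chain carbon gives the series its only read exchange of a group at this position, and the step is a number 0.30 log units lower from compound 3 to compound 4 (within the scatter). Compounds 2 and 3 could speak only to configuration at this carbon, whereas this pair shows that the aromatic ring and the fluorine of the 4-fluorophenyl group can be exchanged for the acyclic isobutyl group without the read-out leaving the scatter, at least with the rest of compound 3 held fixed. No measured property in these notes accounts for this outcome or bears on its cause.

Going by these compounds, it remains open whether a group of another kind on this carbon, such as an amine, a carboxylic acid or a longer chain, would also stay within the scatter of compound 3. Also open, on these data alone, are whether the configuration at this carbon is as silent with isobutyl as with 4-fluorophenyl, and whether the same exchange behaves alike on the core of compound 1.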